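The source may hold more compounds than are shown below. What is called first, only, known or untested is meant among the compounds shown, and "the series" means these compounds.

In a functional assay on HT-29 cells (Homo sapiens) for inhibition, read by MTT assay, with a stated time of 72 h (a higher number here means a weaker inhibitor, a lower number a stronger inhibitor), compound 1, `COc1cc(NC(=O)/C=C/c2cccc(OCc3ccccc3)c2)cc(OC)c1OC`, gives 3600 nM. For the measured compounds named here, the only other measured compound, compound 2, `C=C(Br)C(=O)Nc1ccc(/C=C/C(=O)Nc2ccc(OC)cc2)cc1`, gives 3100 nM. These two values lie within the usual scatter of each other, so compound 1 stands with compound 2 and neither can be ranked above the other. The two compounds do not differ in just one place, so the measurements show no single structural change on its own.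

Compound 3, `COc1cc(NC(=O)/C=C/c2cccc(N)c2)cc(OC)c1OC`, keeps the core of compound 1 and has amino in place of benzyloxy on an aromatic carbon, meta to a large group: amino in place of benzyloxy on an aromatic carbon. No measurement here tests this change, so what follows is a judgement based on its size and on the 3600 nM of compound 1 as the starting point. A moderate move towards a weaker inhibitor in this assay is expected, and the uncertainty is wide. The expected step is a 3.3-fold higher number from compound 1 to compound 3 (0.52 log units; beyond the scatter). For compound 3, the estimated value is 12000 nM, with an expected range of 3000 nM to 48000 nM.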

Compound 3, half-maximal inhibitory concentration: 63100 nM
Estimate against measurement, compound 3: 5.3-fold (0.72 log units) below; the measured number lies above the stated range.
By their numbers in this assay, from the lowest: compounds 2 and 1 (each within the scatter of the next); then compound 3.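

In this assay, the exchange of benzyloxy for amino on this aromatic carbon, meta to a large group, comes with an 18-fold higher number from compound 1 to compound 3 (1.24 log units; beyond the scatter), so the first single change measured on the core of compound 1 shows that this position is far from indifferent to the group it carries. The step is large and beyond the scatter, but one exchange alters several things at once: it removes a six-membered aromatic ring of carbon only and the oxygen that links it, and it brings in a hydrogen-bond donor, so the result cannot assign the loss to any one of these. No measured evidence accounts for the size of this step.

The compounds shown leave open whether the aromatic ring of benzyloxy, its oxygen link or the amino group itself sets the result, and a phenyl, methoxy or benzylamino group on the same carbon would begin to separate these. They also leave open whether the step holds only on this core, since compound 2 differs from both other compounds in more than one place.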